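Moving One Pyridine Nitrogen in a Potent Thiophene Compound

The source may report more compounds than this note shows. Statements on the series, on what has been measured and on what is new or still open speak of the compounds shown alone.

For the measured compounds named here, in a functional assay on SK-MEL-2 cells (Homo sapiens) for antiproliferative activity (a lower number here means a stronger inhibitor of growth, a higher number a weaker inhibitor of growth), compound 3 `c1ccc(-c2cc(-c3cccs3)cc(-c3ccccn3)n2)nc1` gives 1.8 ug/mL, the lowest number so far. Compound 1 `c1ccc(-c2cc(-c3cccnc3)nc(-c3ccccn3)c2)cc1` gives 89.2 ug/mL. Compound 2 `c1ccc(-c2cc(-c3ccsc3)cc(-c3cccnc3)n2)nc1` reads > 100 ug/mL, which is a limit of the assay and not a number.

The next structure, compound 4 `c1ccc(-c2cc(-c3cccs3)cc(-c3cccnc3)n2)nc1`, keeps the atoms of compound 3 but joins them differently: pyridin-3-yl in place of pyridin-2-yl on an aromatic carbon. Pyridin-3-yl stands in place of pyridin-2-yl on an aromatic carbon.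

Going by the values given here, no measured step tests this change directly. The only one, an at least 1.1-fold higher number from compound 1 to compound 2 (0.04 log units; that floor lies within the scatter), concerns thiophen-3-yl in place of phenyl, so it says little here. The expectation rests instead on compound 1, which carries pyridin-3-yl and gives 89.2 ug/mL. Compound 2 carries that group too and also shows only weak inhibition. Both differ from compound 3 in more than one place, so this evidence is indirect.

A sizeable rise in the number is therefore expected, estimated as an 11-fold higher number from compound 3 to compound 4 (1.05 log units; beyond the scatter). For compound 4 the estimated value in this assay is 20 ug/mL, within a range of 3 ug/mL to 100 ug/mL.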

Compound 4, concentration for 50% growth inhibition: 77.7 ug/mL
Estimate against measurement, compound 4: 3.9-fold (0.59 log units) below; the range from low to high includes it.
By their numbers in this assay, from the lowest: compound 3; then compounds 4 and 1 (each within the scatter of the next). At a limit, above all of these: compound 2.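

The direct test of this position comes with compound 4: in this assay, pyridin-3-yl in place of pyridin-2-yl gives a 43-fold higher number from compound 3 to compound 4 (1.64 log units; beyond the scatter), so the low number of compound 3 does not survive this shift of one ring nitrogen, even with thiophen-2-yl kept. Thiophen-2-yl in place of phenyl on an aromatic carbon gives a 1.1-fold lower number from compound 1 to compound 4 (0.06 log units; within the scatter), so with pyridin-3-yl present this swap shows no change beyond the scatter. Compound 2 reads > 100 ug/mL, a limit of the assay and not a number: the limit of > 100 ug/mL in this assay, at which 1 of the 4 values shown sits. Thiophen-2-yl in place of thiophen-3-yl on an aromatic carbon gives an at least 1.2-fold lower number from compound 2 to compound 4 (0.10 log units; that floor lies within the scatter), which fixes only a floor for this step.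

Going by these compounds, it remains open whether thiophen-2-yl contributes to the low number of compound 3 or whether phenyl would serve as well alongside pyridin-2-yl. On these data alone, how pyridin-4-yl, or an amine on the pyridin-2-yl group, would fare at this position also remains open.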